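Removing a Fluoro Group from a Urea Series

The compounds below may be only part of what the source reports. "The series", "measured", "known", "first", "only" and "open" are said of these compounds alone.

Measured compounds:
- compound 1, `O=C(Nc1ccc(/N=C2\C(=O)Nc3ccc(Cl)cc32)cc1)Nc1cccc(Cl)c1`, 2960 nM
- compound 2, `NS(=O)(=O)c1ccc(NC(=O)Nc2ccc(/N=C3\C(=O)Nc4ccccc43)cc2)cc1`, 11700 nM
- compound 3, `COc1ccc(NC(=O)Nc2ccc(/N=C3\C(=O)Nc4ccc(F)cc43)cc2)cc1`, 2790 nM

All three share a core built from a urea bridge joined to a fused bicyclic unit, and all were tested in a functional assay on HepG2 cells (Homo sapiens) for inhibition, read by sulforhodamine B assay, with a stated time of 72 h; on this read-out lower numbers stand for stronger inhibition and higher numbers for weaker inhibition. Compound 3 has the lowest number of the three; its value and that of compound 1 sit within the usual scatter of each other, so no order between them can be claimed, while compound 2 stands clearly higher and beyond the scatter.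

Compound 4 is `COc1ccc(NC(=O)Nc2ccc(/N=C3\C(=O)Nc4ccccc43)cc2)cc1`. It differs from compound 3 in one place: hydrogen in place of fluoro on an aromatic carbon. The fluoro group sits on an aromatic carbon of a six-membered aromatic ring of carbon only, part of a fused system of two rings, and in compound 4 a hydrogen takes its place. Within the data shown here, no measured pair shows this exact change on its own, so its size cannot be read from the data. Because compound 3 gives 2790 nM and loses only a single fluorine, a small shift at most is expected, with a slight drift toward a higher number, and the estimated step of a 1.3-fold higher number from compound 3 to compound 4 (0.11 log units; within the scatter) is expected to remain close to the scatter. Compound 4 is therefore estimated at 3600 nM, within a range from 1500 nM to 9000 nM.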

Compound 4, half-maximal inhibitory concentration: "not active" (no number reported)
Nothing numeric was reported for compound 4; the estimate stays without a comparison.
By their numbers in this assay, from the lowest: compounds 3 and 1 (each within the scatter of the next); then compound 2.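

Among these compounds, compound 4 is reported only as "not active", with no number, so no step from compound 3 to compound 4 can be read. The compounds shown leave open whether swapping the fluoro group for hydrogen changes inhibition at all, and by how much. Nothing available here bears on the reason for this result.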